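The source may report more compounds than this note shows. Statements on the series, on what has been measured and on what is new or still open speak of the compounds shown alone.

Measured so far:
compound 1, `CC1CN(CCn2ccc3ccc(Br)cc32)CCN1`, 52%
compound 2, `CN1CCCN(CCn2ccc3ccc(F)cc32)CC1`, 60%

Both numbers come from an assay on HEK293 cells for binding affinity to 5-hydroxytryptamine receptor 7 (Homo sapiens), read by radioligand binding, tested at 1 uM; on this read-out higher numbers stand for more inhibition at the one concentration tested (going by the name of the read-out) and lower numbers for less inhibition. Compound 2, with 60%, and compound 1, with 52%, lie within the usual scatter of each other, so the data do not set one apart from the other. Compound 2 is the starting point of the step considered here. The two compounds differ in more than one place, so nothing is said about the size or cause of any step between them; only their two values are shown.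

Compound 3, `CC(C)c1ccc2ccn(CCN3CCCN(C)CC3)c2c1`, has not been measured yet. Compared with compound 2, the change is isopropyl in place of fluoro on an aromatic carbon. Going by the values given here, no measured pair shows this change on its own, so its effect is unknown; a new group enters at the same aromatic carbon where fluoro stood. With nothing to guide direction, the step from compound 2 to compound 3, estimated as a number 5 percentage points lower from compound 2 to compound 3 (within the scatter), is expected to stay within the scatter, with wide uncertainty either way. Compound 3 is therefore estimated at 55%, within a range from 30% to 80%.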

Compound 3, a percentage reported as inhibition, at one concentration (the size of the read-out at that concentration, not a potency): 72%
Compound 3: the middle estimate sits 17 percentage points below what was measured; measured number inside the range.
By their numbers in this assay, from the lowest: compounds 1 and 2 (each within the scatter of the next); then compound 3.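

In this assay, going by these compounds alone, the swap of fluoro for isopropyl on this aromatic carbon gives a number 12 percentage points higher from compound 2 to compound 3 (beyond the scatter) and is the only change here that can be read on its own. It shows that this place on the six-membered aromatic ring can carry a group of three heavy atoms instead of a single fluorine without losing inhibition at the one concentration tested, and that the larger group here goes with a higher number. Nothing measured here speaks to what lies behind this rise.

A single pair cannot separate the size of the new group from its kind, so a methoxy group, an amine or a longer carbon chain on the same aromatic carbon would be needed to show whether the number keeps rising, levels off or falls. As far as these compounds go, compound 1 differs from compound 2 in more than one place, so that step cannot be read, and whether isopropyl would bring a similar change on the core of compound 1 also stays open.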